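The compounds below may be only part of what the source reports. "The series", "measured", "known", "first", "only" and "open" are said of these compounds alone.

Series notes. Within the data shown here, in an assay on isolated protein for inhibition of serine protease 1 (Homo sapiens), tested at 100 uM (on this read-out lower numbers stand for less inhibition and higher numbers for more inhibition at the one concentration tested (going by the name of the read-out)), compound 2 `CC1CCCC(C)N1CCCCCN1C(=O)C(c2ccc(Cl)cc2)Oc2ccccc21` gives 46%, the highest of the three numbers so far; compound 3 `CC1CCCC(C)N1CCCCCN1C(=O)C(c2ccc(C(=N)NO)cc2)Oc2ccccc21` gives 8% and compound 1 `CC1CCCC(C)N1CCCCCN1C(=O)C(c2ccccc2)Oc2ccccc21` gives 2.8%. Compound 4 `CC1CCCC(C)N1CCCCCN1C(=O)C(c2cccc(C(=N)S)c2)Oc2ccccc21` is not yet measured. It differs from compound 2 by a group of 9 heavy atoms (7 carbon, 1 nitrogen, 1 sulfur; one six-membered aromatic ring of carbon only) in place of a group of 7 heavy atoms (6 carbon, 1 chlorine; one six-membered aromatic ring of carbon only), on a saturated ring carbon. Among the measured compounds shown here, two measured steps bear on this change. Adding the chloro, a number 43.2 percentage points higher from compound 1 to compound 2 (beyond the scatter), brought the one large gain; exchanging it for a group of 4 heavy atoms (1 carbon, 2 nitrogen, 1 oxygen; no ring), a number 38 percentage points lower from compound 2 to compound 3 (beyond the scatter), gave most of that back, while a number 5.2 percentage points higher from compound 1 to compound 3 (within the scatter). Compound 4 likewise loses the chlorine and takes on a group with two hydrogen-bond donors and one acceptor, so a large downward step is expected, a number 36 percentage points lower from compound 2 to compound 4 (beyond the scatter). The estimate for compound 4 in this assay is 10%, range 0% to 35%.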

Compound 4, a percentage reported as inhibition, at one concentration (the size of the read-out at that concentration, not a potency): 5.2%
Compound 4: middle estimate off by 4.8 percentage points, on the high side; the measured number falls inside the stated range.
By their numbers in this assay, from the lowest: compounds 1, 4 and 3 (each within the scatter of the next); then compound 2.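

In this assay, replacing the 4-chlorophenyl with the new sulfur-bearing group removes nearly all of the gain seen with the chloro, with a number 40.8 percentage points lower from compound 2 to compound 4 (beyond the scatter). This group gives no number separable from the other two compounds without chlorine, with a number 2.4 percentage points higher from compound 1 to compound 4 (within the scatter) and a number 2.8 percentage points lower from compound 3 to compound 4 (within the scatter), so among the four compounds only compound 2 stands apart. Nothing on hand explains the loss. From the compounds shown here alone, whether a 4-bromophenyl or 4-methylphenyl group at this position would keep the number of compound 2 remains open.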